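Methyl in Place of Chloro: Compound 3 to Compound 4

This account rests on a few compounds, and the source may have more. Where it says the series, first, only, none or still open, it means among the compounds named here.

Of the compounds shown here, three have been measured in a functional assay on DU-145 cells (Homo sapiens) for inhibition, read by trypan blue exclusion, with a stated time of 96 h; a higher number here means a weaker inhibitor of growth, a lower number a stronger inhibitor of growth. Compound 3 (`Cc1ccc(/C=C(/SCc2ccc(Cl)cc2)C(=O)c2ccc(Cl)cc2)s1`) gives 50000 nM, level with compound 2 (`Cc1ccc(CS/C(=C/c2c(O)cc(O)cc2O)C(=O)c2ccc(Cl)cc2)cc1`) at 50000 nM. Compound 1 (`Cc1ccc(CS/C(=C/c2ccc(F)c(C)c2)C(=O)c2ccc(Cl)cc2)cc1`) gives 25000 nM, and all three values lie within the scatter of each other.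

The next compound, compound 4 (`Cc1ccc(CS/C(=C/c2ccc(C)s2)C(=O)c2ccc(Cl)cc2)cc1`), differs from compound 3 by one exchange: methyl in place of chloro on an aromatic carbon. Seen one bond further out, this exchange turns 4-chlorobenzyl into 4-methylbenzyl. Among the compounds with values here, no measured pair makes this exchange directly. Within the data shown here, the only measured step is a 2.0-fold higher number from compound 1 to compound 2 (0.30 log units; within the scatter), and it lies elsewhere in the molecule. It offers indirect guidance at most, since even that larger replacement stayed within the scatter.

The expectation is therefore a 1.3-fold lower number from compound 3 to compound 4 (0.10 log units; within the scatter), with no step beyond the scatter. For compound 4 the estimated value in this assay is 40000 nM, with an expected range from 16000 nM to 100000 nM.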

Compound 4, concentration for 50% growth inhibition: 50000 nM
Compound 4: the middle estimate sits 1.3-fold (0.10 log units) below what was measured; the range from low to high includes it.
By their numbers in this assay, from the lowest: compounds 1, 2, 3 and 4 (each within the scatter of the next).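

In this assay, within the data shown here, no change at the digits printed from compound 3 to compound 4 (within the scatter) gives the first direct reading at this position, on an aromatic carbon para to a large group: turning 4-chlorobenzyl into 4-methylbenzyl leaves the number unchanged. Among these compounds, the 5-methylthiophen-2-yl group, which the earlier comparisons did not cover on the benzyl-bearing side with methyl, can also be read against the other groups on the double-bonded chain carbon, giving no change at the digits printed from compound 2 to compound 4 (within the scatter) and a 2.0-fold higher number from compound 1 to compound 4 (0.30 log units; within the scatter). Neither of these steps leaves the scatter, so no exchange shown so far separates any of the compounds.

As far as these compounds go, whether an amine or a carboxylic acid at this position would move the number beyond the scatter remains open. Nothing shown accounts for the result of this exchange.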